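Extending the aryl ether by one carbon on the strongest compound

A few compounds are considered here, and "the series" means these few. Any claim that something is new, unique, unknown or untested is made for them only; others in the source may bear on it.

A pair of compounds sharing a core has been measured in an assay on cells (Ventricular myocyte) for inhibition of potassium voltage-gated channel subfamily KQT member 1 (Cavia porcellus), read by patch clamp; on this read-out higher numbers stand for weaker inhibition and lower numbers for stronger inhibition. Compound 1 `CCOc1ccc2c(c1)/C(=N/N1CC(=O)N(CCCCN3CCCCC3)C1=O)CCO2` carries an ethoxy group on the aromatic ring and a four-carbon chain ending in a piperidine; in this assay compound 1 gives 1040 nM. Compound 2 `COc1ccc2c(c1)/C(=N/N1CC(=O)N(CCCN3CCN(C)CC3)C1=O)CCO2` carries a methoxy group instead and a three-carbon chain ending in a methylpiperazine; in this assay compound 2 gives 1.9 nM, the lowest of the two numbers and far beyond the usual scatter from compound 1. These two compounds differ in two places at once. Their gap cannot be traced to either place alone.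

Compound 3 `CCOc1ccc2c(c1)/C(=N/N1CC(=O)N(CCCN3CCN(C)CC3)C1=O)CCO2` keeps the methylpiperazine chain of compound 2 and differs from it in one place: methyl in place of hydrogen on a saturated chain carbon bound to an oxygen on an aromatic ring. Among the compounds with values here, no measured pair isolates this change, so the direction of the step is uncertain. The expectation is a modest shift, a 3.2-fold higher number from compound 2 to compound 3 (0.50 log units; beyond the scatter), with the ethoxy-bearing compound 1 and its value 1040 nM giving only a weak hint of a loss. The estimate for compound 3 in this assay is 6 nM, ranging from 1.5 nM to 40 nM.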

Compound 3, half-maximal inhibitory concentration: 26.9 nM
Beside the measured number, compound 3's estimate is 4.5-fold (0.65 log units) below it, and the stated range covers the measured number.
By their numbers in this assay, from the lowest: compound 2; then compound 3; then compound 1.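

In this assay, the methoxy to ethoxy change can now be read on its own: with the methylpiperazine chain held fixed, methyl in place of hydrogen on a saturated chain carbon bound to an oxygen on an aromatic ring gives a 14-fold higher number from compound 2 to compound 3 (1.15 log units; beyond the scatter), a large loss of inhibition from a small addition. With the ethoxy group held fixed, 4-methylpiperazin-1-yl in place of (piperidin-1-yl)methyl gives a 39-fold lower number from compound 1 to compound 3 (1.59 log units; beyond the scatter), so the wide gap between the first two compounds, which differ in two places, now resolves into two single-place steps that each lie beyond the usual scatter. Nothing available here explains why either change has such an effect on this channel.

As far as these compounds go, each step is seen against only one version of the rest of the molecule, so it remains open whether the ether change would have the same size alongside the piperidine chain. Also open, from the compounds shown here alone, is how inhibition would respond to a longer propoxy group or a branched isopropoxy group on the aromatic ring, and so whether the loss continues beyond ethoxy.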